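This account rests on a few compounds, and the source may have more. Where it says the series, first, only, none or still open, it means among the compounds named here.

Compound 1 `N[C@]1(C(=O)O)[C@H]2[C@@H](C[C@H]1OCc1ccccc1Cl)[C@]2(F)C(=O)O`: in an assay on CHO cells for binding affinity to metabotropic glutamate receptor 2 (Rattus norvegicus) (a higher number here means a weaker inhibitor, a lower number a stronger inhibitor), compound 1 gives 4.99 nM.
Compound 2 `N[C@]1(C(=O)O)[C@H]2[C@@H](C[C@H]1OCc1c(F)cccc1F)[C@]2(F)C(=O)O`: in this assay compound 2 gives 7.02 nM.

Among these two numbers compound 2 stands beside compound 1, the only other measured compound; the step of a 1.4-fold higher number from compound 1 to compound 2 (0.15 log units; within the scatter) lies within the scatter, so the two cannot be told apart on these data. Compound 3 `N[C@]1(C(=O)O)[C@H]2[C@@H](C[C@H]1OCc1ccc(Cl)cc1Cl)[C@]2(F)C(=O)O` is not yet measured. It differs from compound 2 in one place: 2,4-dichlorophenyl in place of 2,6-difluorophenyl on a saturated chain carbon bound to an oxygen on a saturated carbon. Within the data shown here, the only measured step that bears on this exchange is the one from compound 1 to compound 2, which also swapped one halogenated phenyl for another on the same saturated chain carbon, and that step, a 1.4-fold higher number from compound 1 to compound 2 (0.15 log units; within the scatter), was within the scatter. He therefore expects no step beyond the scatter in this assay for compound 3, an estimated 1.2-fold lower number from compound 2 to compound 3 (0.07 log units; within the scatter). His estimate for compound 3 in this assay is 6 nM, expected to fall between 2.5 nM and 15 nM.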

Compound 3, inhibition constant: 3.89 nM
The estimate for compound 3 lay 1.5-fold (0.19 log units) above the measured number; the range from low to high includes it.
By their numbers in this assay, from the lowest: compounds 3, 1 and 2 (each within the scatter of the next).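

In this assay, 2,4-dichlorophenyl in place of 2,6-difluorophenyl on a saturated chain carbon bound to an oxygen on a saturated carbon gives a 1.8-fold lower number from compound 2 to compound 3 (0.26 log units; within the scatter) and so stays within the scatter, even though both halogen atoms differ in this exchange. Chloro in place of hydrogen on an aromatic carbon gives a 1.3-fold lower number from compound 1 to compound 3 (0.11 log units; within the scatter) and also stays within the scatter, so the three halogenated phenyl groups shown at this position cannot be told apart on these data. No measurement at hand offers an account of this result.

All three compounds carry a halogenated phenyl here, which leaves open how an unsubstituted phenyl, or a phenyl bearing an amine or a carboxylic acid, would read in this assay. As far as these compounds go, whether a longer chain in place of the saturated chain carbon would keep the number within the scatter also remains open.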